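Morpholine amide carried over to the second indole core

The source may report more compounds than this note shows. Statements on the series, on what has been measured and on what is new or still open speak of the compounds shown alone.

Three compounds were tested in an assay on a protein complex for inhibition of CDK8/Cyclin C (Homo sapiens), with a stated time of 1 h, tested at 10 uM; a higher number here means more inhibition at the concentration tested (going by the name of the read-out), a lower number less inhibition. Compound 1 `O=C(/C=C/c1ccncc1-c1ccc2[nH]ccc2c1)N1CCOCC1` gives 97%, compound 2 `CCOC(=O)/C=C/c1ccncc1-c1ccc2[nH]ccc2c1` gives 100%, and compound 3 `CCOC(=O)/C=C/c1ccncc1-c1ccc2cc[nH]c2c1` gives 104%. Compound 2 and compound 3 are built from the same atoms joined differently; the difference between the two cores is not broken down here. The change morpholin-4-yl in place of ethoxy on a carbonyl carbon produced a number 3 percentage points lower from compound 2 to compound 1 (within the scatter). Compound 4 `O=C(/C=C/c1ccncc1-c1ccc2cc[nH]c2c1)N1CCOCC1` has not yet been measured in this assay; it differs from compound 3 by morpholin-4-yl in place of ethoxy on a carbonyl carbon, the same change made on the core of compound 3. Because the step of a number 3 percentage points lower from compound 2 to compound 1 (within the scatter) stayed within the scatter, and because compound 3 already gives 104%, compound 4 is expected to give 100%, somewhere between 90% and 108%. That estimate means an expected step of a number 4 percentage points lower from compound 3 to compound 4 (within the scatter).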

Compound 4, a percentage reported as inhibition, at one concentration (the size of the read-out at that concentration, not a potency): 102%
For compound 4 the middle estimate is 2 percentage points below the measured one; measured number inside the range.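

In this assay, morpholin-4-yl in place of ethoxy on a carbonyl carbon gave a number 2 percentage points lower from compound 3 to compound 4 (within the scatter), and the change read the same way on both cores: the same change on two cores in this assay, a number 3 percentage points lower (within the scatter) from compound 2 to compound 1 and a number 2 percentage points lower (within the scatter) from compound 3 to compound 4, 1 percentage points apart, within the scatter of two such steps. On these two cores, then, the change carried over with no step beyond the scatter. This does not show that the two cores respond alike in potency, as each number is a read-out at one concentration and not a potency.

The compounds shown leave open how other groups on the carbonyl carbon, such as piperidine, dimethylamino or the hydroxy group of a carboxylic acid, would read on either core. They also leave open whether the change carries over to any further core.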